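Methoxymethyl on Compound 3: Expecting Little Change

The source may hold more compounds than are shown below. What is called first, only, known or untested is meant among the compounds shown, and "the series" means these compounds.

In an ADME assay (liver, Mus musculus) for metabolic stability, using microsomes (on this read-out lower numbers stand for a shorter-lived compound and higher numbers for a longer-lived compound), compound 1 (`C=CC(=O)Nc1cccc(CNc2nc(Nc3cnn(CCOC)c3)ncc2Cl)c1`) gives 0.055 h and compound 2 (`C=C(C)C(=O)Nc1cccc(CNc2nc(Nc3cnn(CCOC)c3)ncc2Cl)c1`) gives 0.035 h while compound 3 (`C=CC(=O)Nc1ccc(CNc2nc(Nc3cnn(C)c3)ncc2Cl)cc1`) gives 0.0517 h and so lies within the scatter of both. Compound 4 (`C=CC(=O)Nc1ccc(CNc2nc(Nc3cnn(CCOC)c3)ncc2Cl)cc1`) differs from compound 3 by one change (methoxymethyl in place of hydrogen on a saturated chain carbon bound to an aromatic nitrogen), methoxymethyl in place of hydrogen on a saturated chain carbon bound to an aromatic nitrogen, which turns methyl into 2-methoxyethyl. Going by the values given here, no measured step makes this change. Among the compounds with values here, the one measured step (a 1.6-fold lower number from compound 1 to compound 2 (0.20 log units; within the scatter)) lies elsewhere and stays within the scatter. Compound 1 already carries 2-methoxyethyl, and its 0.055 h lies within the scatter of compound 3. The expected step in this assay is therefore none beyond the scatter (a 1.0-fold lower number from compound 3 to compound 4 (0.01 log units; within the scatter)). For compound 4 the estimate is 0.05 h with an expected range of 0.027 h to 0.09 h in repeated measurements.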

Compound 4, half-life: 0.0467 h
Beside the measured number, compound 4's estimate is 1.1-fold (0.03 log units) above it; measured number inside the range.
By their numbers in this assay, from the lowest: compounds 2, 4, 3 and 1 (each within the scatter of the next).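

this assay shows a 1.1-fold lower number from compound 3 to compound 4 (0.04 log units; within the scatter) for methoxymethyl in place of hydrogen on a saturated chain carbon bound to an aromatic nitrogen, the first direct reading of this change. In this one pair, then, methyl and 2-methoxyethyl cannot be told apart by half-life, and the added atoms leave no mark beyond the scatter. Nothing given here speaks to the reason for this result. From the compounds shown here alone, whether an amine, a carboxylic acid or a longer chain in this place would read the same stays open.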